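This account rests on a few compounds, and the source may have more. Where it says the series, first, only, none or still open, it means among the compounds named here.

Values so far in a physicochemical assay for solubility, in phosphate buffer, at pH 7.4 (on this read-out lower numbers stand for lower solubility and higher numbers for higher solubility), for the measured compounds:
- Compound 1 `Cc1cnc(C(=O)Nc2cc(-c3ccnc(Nc4ccccc4)c3)ccn2)cn1`: 40000 nM
- Compound 2 `O=C(Nc1cc(-c2ccnc(Nc3ccccc3)c2)ccn1)c1cccnc1`: 17000 nM

Of these two, compound 2 stands lowest, with its 17000 nM as the lower number. Compound 3 `O=C(Nc1cc(-c2ccnc(Nc3ccccc3)c2)ccn1)c1ccco1` has not yet been measured. It differs from compound 2 by furan-2-yl in place of pyridin-3-yl on a carbonyl carbon.

Among the compounds with values here, only one measured step bears on this change. It is a 2.4-fold lower number from compound 1 to compound 2 (0.37 log units; beyond the scatter), at the same place, and it is modest though beyond the scatter. Within the data shown here, no measured compound carries furan-2-yl, so the direction remains open. A step no larger than that one is expected, leaning slightly downward in this assay. The expected step is a 1.3-fold lower number from compound 2 to compound 3 (0.12 log units; within the scatter) and it may not clear the scatter. For compound 3 the estimate is 13000 nM, with an expected range of 5000 nM to 32000 nM and no more than that claimed.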

Compound 3, solubility: 4000 nM
For compound 3 the middle estimate is 3.3-fold (0.51 log units) above the measured one; measured number below the stated range.
By their numbers in this assay, from the lowest: compound 3; then compound 2; then compound 1.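

In this assay the group on the carbonyl carbon proved able to move the number further than the earlier pair had shown, with a 4.3-fold lower number from compound 2 to compound 3 (0.63 log units; beyond the scatter) when furan-2-yl takes the place of pyridin-3-yl. Measured against the 5-methylpyrazin-2-yl group, the same furan-2-yl shows a 10-fold lower number from compound 1 to compound 3 (1.00 log units; beyond the scatter) and leaves compound 3 lowest of the three. So, among these compounds, the exchange of one aromatic ring for another at this place produces steps beyond the scatter, and the five-membered ring stands at the low end. Nothing measured here accounts for this order.

Going by these compounds, whether a phenyl or thiophen-2-yl group on the same carbonyl carbon would fall near furan-2-yl remains open. So does the reading for a ring carrying an amine or a carboxylic acid, and whether these steps would hold with a different group elsewhere on the shared core.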